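Isopropyl for propyl on sulfur: cytotoxicity expectation

The source may report more compounds than this note shows. Statements on the series, on what has been measured and on what is new or still open speak of the compounds shown alone.

Measured compounds:
- compound 1, `Nc1nc(OCC(F)(F)F)c2ncn(/C=C3/CC3(CO)CO)c2n1`: > 300000 nM
- compound 2, `C=CCOc1nc(N)nc2c1ncn2/C=C1/CC1(CO)CO`: > 300000 nM
- compound 3, `CCCSc1nc(N)nc2c1ncn2/C=C1/CC1(CO)CO`: > 300000 nM

Compound 3, `CCCSc1nc(N)nc2c1ncn2/C=C1/CC1(CO)CO`, is the starting point. In an ADME assay on HFF cells (Homo sapiens) for cytotoxicity, with a stated time of 8 days (on this read-out higher numbers stand for lower toxicity in this test and lower numbers for higher toxicity in this test), compound 3 reaches only the limit of the test, > 300000 nM, and no number. Compound 1, `Nc1nc(OCC(F)(F)F)c2ncn(/C=C3/CC3(CO)CO)c2n1`, likewise sits at a limit, > 300000 nM. Compound 2, `C=CCOc1nc(N)nc2c1ncn2/C=C1/CC1(CO)CO`, also gives only a limit, > 300000 nM. All three shown values therefore rest at the same limit, (the limit of > 300000 nM in this assay, at which 3 of the 3 values shown sit), so every measured step is unreadable: a step that the two limits leave unreadable from compound 1 to compound 2, a step that the two limits leave unreadable from compound 1 to compound 3 and a step that the two limits leave unreadable from compound 2 to compound 3.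

Compound 4, `CC(C)Sc1nc(N)nc2c1ncn2/C=C1/CC1(CO)CO`, is the compound not yet measured. It differs from compound 3 by isopropyl in place of propyl on a sulfur, on a sulfur whose other neighbour is an aromatic carbon. No measured step speaks to a change of this kind, and the three shown values give no direction. Since every compound shown sits at the limit, compound 4 is expected to stay there as well, a step of a number no higher from compound 3 to compound 4 (the limit leaves the size open) in this assay being the estimate. Compound 4 is estimated to give 300000 nM, within a range of 100000 nM to 1000000 nM, most likely reported again only as a limit.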

Compound 4, half-maximal cytotoxic concentration: > 300000 nM
Compound 4: only a limit was reported; the forecaster's own chance of this, stated with the estimate: 85%; the middle value sits exactly at the limit.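

In this assay the steps linking compound 4 to compound 1, compound 2 and compound 3 cannot be read, because all four compounds rest at one limit: the limit of > 300000 nM in this assay, at which 4 of the 4 values shown sit. The compounds shown leave open how far each lies from that limit, and whether isopropyl and propyl on a sulfur differ at all on this read-out.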